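The compounds below may be only part of what the source reports. "The series", "measured", "known", "first", "only" and "open" are said of these compounds alone.

Of the compounds shown here, three built on one shared core have been measured in an assay on mitochondria from L6 cells (Rattus norvegicus) for activation, with a stated time of 90 min; a lower number here means that less compound is needed, a higher number that more compound is needed for the effect. Compound 1 `Oc1nc2nonc2nc1Nc1cccc(C(F)(F)F)c1` gives 13300 nM. Compound 2 `Oc1nc2nonc2nc1Nc1cccc(OC(F)(F)F)c1` gives 5100 nM in this assay. Compound 3 `Oc1nc2nonc2nc1Nc1ccc(C(F)(F)F)cc1F` gives 2600 nM in this assay. The change between the first two is trifluoromethoxy in place of trifluoromethyl on an aromatic carbon, and it produced a 2.6-fold lower number from compound 1 to compound 2 (0.42 log units; beyond the scatter). The difference between the core of compound 1 and the core of compound 3 is not broken down here.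

Compound 4 `Oc1nc2nonc2nc1Nc1ccc(OC(F)(F)F)cc1F` has not yet been measured. It differs from compound 3 by trifluoromethoxy in place of trifluoromethyl on an aromatic carbon. For the measured compounds named here, this is the same kind of change as the one between compound 1 and compound 2, but the surroundings differ: in compound 2 the entering group sits meta to a large group, whereas in compound 4 it sits meta to a fluoro group and para to a large group. Because the earlier step gave a 2.6-fold lower number from compound 1 to compound 2 (0.42 log units; beyond the scatter), the expected step is of similar size, a 2.0-fold lower number from compound 3 to compound 4 (0.30 log units; within the scatter), though a single earlier example and the changed surroundings leave this uncertain. Compound 4 is therefore estimated at 1300 nM in this assay, expected to fall between 500 nM and 3500 nM.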

Compound 4, half-maximal effective concentration: 2300 nM
Compound 4: middle estimate off by 1.8-fold (0.25 log units), on the low side, within the range that was stated.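

In this assay, trifluoromethoxy in place of trifluoromethyl gives a 1.1-fold lower number from compound 3 to compound 4 (0.05 log units; within the scatter), so on this core the change has no effect that can be told apart from the ordinary variation between repeated measurements. Set side by side, the two examples of this change do not differ by more than such variation allows: the same change on two cores in this assay, a 2.6-fold lower number (0.42 log units; beyond the scatter) from compound 1 to compound 2 and a 1.1-fold lower number (0.05 log units; within the scatter) from compound 3 to compound 4, 2.3-fold (0.36 log units) apart, within the scatter of two such steps. For the compounds shown here, this means the results fit a single modest effect carried across both cores, but it does not prove that the effect transfers, and with only two pairs, one step beyond the scatter and one within it, a real dependence on the core can be neither confirmed nor ruled out.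

The compounds shown leave open how the numbers respond when the trifluoromethyl or trifluoromethoxy group gives way to a different kind of group, such as an amine or a carboxylic acid. They also leave open what the fluoro group contributes on its own.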